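From 4-methylphenyl to 3-fluorophenyl on the shared core

This account rests on a few compounds, and the source may have more. Where it says the series, first, only, none or still open, it means among the compounds named here.

In a functional assay on A549 cells (Homo sapiens) for antiproliferative activity, read by MTT assay, with a stated time of 72 h (a higher number here means a weaker inhibitor, a lower number a stronger inhibitor), compound 1 (`CCCNC(=O)c1cc(Oc2ccc(NC(=O)c3nn(-c4ccc(C)cc4)c(=O)cc3C)cc2F)ccn1`) gives 18000 nM. This value lies within the scatter of compound 3 (`CCNC(=O)c1cc(Oc2ccc(NC(=O)c3nn(-c4ccc(C)cc4)c(=O)cc3C)cc2)ccn1`), which gives 11600 nM, and also within the scatter of compound 2 (`CCNC(=O)c1cc(Oc2ccc(NC(=O)c3nn(-c4ccccc4C)c(=O)cc3C)cc2)ccn1`), which gives 34800 nM. Compound 1 therefore cannot be ranked against either of them.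

Compound 4 (`CCCNC(=O)c1cc(Oc2ccc(NC(=O)c3nn(-c4cccc(F)c4)c(=O)cc3C)cc2F)ccn1`) keeps the core of compound 1 but carries 3-fluorophenyl in place of 4-methylphenyl on an aromatic nitrogen.

Going by the values given here, only one measured step touches this group. It is a 3.0-fold lower number from compound 2 to compound 3 (0.48 log units; beyond the scatter), with 4-methylphenyl in place of 2-methylphenyl on an aromatic nitrogen. That modest step shows that the number can respond to a change in this group, but it only relocates a methyl group. Among the compounds with values here, no measured compound carries a fluorine on this phenyl group, so the data give no firm direction for the new change. In this assay, a step no larger than the measured one is expected, and most likely none beyond the scatter. The expected change is a 1.1-fold higher number from compound 1 to compound 4 (0.05 log units; within the scatter). For compound 4 the estimated value is 20000 nM, with an expected range from 9000 nM to 45000 nM.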

Compound 4, half-maximal inhibitory concentration: 7020 nM
Estimate against measurement, compound 4: 2.8-fold (0.45 log units) above; the measured number lies below the stated range.
By their numbers in this assay, from the lowest: compounds 4, 3, 1 and 2 (each within the scatter of the next, the first and the last beyond it).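

In this assay, the change to 3-fluorophenyl gives a 2.6-fold lower number from compound 1 to compound 4 (0.41 log units; beyond the scatter). Going by these compounds alone, until now the only step at this group was a methyl shift on the phenyl group in the ethyl amide series, whereas this step shows that replacing the methyl with a fluorine, on the core of compound 1, also moves the number beyond the scatter, and towards the stronger side. No measurement given here bears on the cause of this step.

Because this single step changes both the substituent and its place on the phenyl group, the compounds shown cannot tell whether the fluorine, its place or the loss of the methyl accounts for the lower number, and they do not show whether the same swap would act alike on the core of compound 3. As far as these compounds go, it also remains open how an unsubstituted phenyl group, or a phenyl group carrying a chlorine, a methoxy group or an amine, would compare with the 3-fluorophenyl of compound 4.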